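Phenoxy Replacement in Compound 2: Tolerated Concentration Outlook

The compounds below may be only part of what the source reports. "The series", "measured", "known", "first", "only" and "open" are said of these compounds alone.

In a toxicity assay on MT4 cells (Homo sapiens) for cytotoxicity, read by MTT assay, with a stated time of 5 days (a higher number here means that more compound is tolerated, a lower number that less compound is tolerated), compound 1 `Cc1ccc(C(C)C)c(OCc2nnc(SCC(=O)Nc3ccc(Cl)cc3)n2Cc2ccccc2)c1` gives 65.9 ug/mL, compound 2 `Cc1ccc(C(C)C)c(OCc2nnc(SCC(=O)Nc3ccc(Br)cc3)n2Cc2ccccc2)c1` gives 66.7 ug/mL and compound 3 `Cc1ccc(C(C)C)c(OCc2nnc(SCC(=O)Nc3ccc([N+](=O)[O-])cc3)n2Cc2ccccc2)c1` gives 11.2 ug/mL. Compound 2 holds the highest of the three numbers, though the step of a 1.0-fold higher number from compound 1 to compound 2 (0.01 log units; within the scatter) lies within the scatter and so carries no order. Among the compounds with values here, the one change that moved the numbers was the nitro group: a 5.9-fold lower number from compound 1 to compound 3 (0.77 log units; beyond the scatter) and a 6.0-fold lower number from compound 2 to compound 3 (0.77 log units; beyond the scatter).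

Compound 4 `CC(=O)Nc1ccc(OCc2nnc(SCC(=O)Nc3ccc(Br)cc3)n2Cc2ccccc2)cc1` differs from compound 2 by 4-acetamidophenyl in place of 2-isopropyl-5-methylphenyl on an oxygen on a saturated carbon. Within the data shown here, every measured step in this set alters the substituent on the anilide ring; none touches the phenoxy part, so no measured step bears directly on this change. The halogen-for-halogen step stayed within the scatter and only the nitro step moved the numbers, so for compound 4 the step of a 1.3-fold lower number from compound 2 to compound 4 (0.13 log units; within the scatter) in this assay is expected to stay within the scatter or fall only modestly. Compound 4 is estimated at 50 ug/mL, with a range from 20 ug/mL to 110 ug/mL.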

Compound 4, half-maximal cytotoxic concentration: >= 3.99 ug/mL
Compound 4: a limit, no number (the forecaster's own chance of this, stated with the estimate: 15%); the middle value does not contradict the limit.
By their numbers in this assay, from the lowest: compound 3; then compounds 1 and 2 (each within the scatter of the next).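

In this assay compound 4 gives >= 3.99 ug/mL, which is a limit and not a number, so the step from compound 2 to compound 4 cannot be read. The compounds shown leave open how 4-acetamidophenyl in place of 2-isopropyl-5-methylphenyl shifts the tolerated concentration.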